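The source may report more compounds than this note shows. Statements on the series, on what has been measured and on what is new or still open speak of the compounds shown alone.

The measured compounds and their values in a functional assay on cells (Platelet, Homo sapiens) for inhibition (a higher number here means a weaker inhibitor, a lower number a stronger inhibitor), are these.
Compound 1, `CCOC(=O)c1ccc(-c2nn(Cc3ccc(Cl)cc3)c3ccccc23)cc1`, gives > 10000 nM, which is a limit of the assay and not a number.
Compound 2, `CC(C)NC(=O)c1ccc(-c2nn(Cc3ccccc3)c3ccccc23)cc1`, gives > 10000 nM, likewise only a limit.
Compound 3, `CO/N=C\c1ccc(-c2nn(Cc3ccccc3)c3ccccc23)cc1`, gives > 10000 nM, again a limit.

Compound 1 therefore stands at the limit of > 10000 nM in this assay, at which 3 of the 3 values shown sit. On the numbers shown nothing separates it from compound 2 or compound 3, since every value is the same limit. Within the data shown here, the single step between measured compounds, a step that the two limits leave unreadable from compound 2 to compound 3, concerns a group on an aromatic carbon at the far end of the shared core and gives no readable size.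

The unmeasured compound 4 is `CCOC(=O)c1ccc(-c2nn(-c3ccccc3)c3ccccc23)cc1`. It differs from compound 1 in this way: phenyl in place of 4-chlorobenzyl on an aromatic nitrogen. Among the measured compounds shown here, none of the measured steps touches the aromatic nitrogen of the core, and the one step that exists is unreadable, so no measured step bears on this change, and no direction beyond the scatter can be drawn from the data. The most that can be said is that every compound sharing this core has sat at the limit so far. Compound 4 is therefore expected to give about 20000 nM, within a range from 5000 nM to 100000 nM. That estimate means an expected step that the limit leaves unreadable from compound 1 to compound 4, most probably reported as another limit.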

Compound 4, half-maximal inhibitory concentration: > 10000 nM
Compound 4: no number, only a limit (the forecaster's own chance of this, stated with the estimate: 80%); the middle value does not contradict the limit.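

In this assay compound 4 gives > 10000 nM, again a limit of the assay and not a number. No step can be read between compound 1 and compound 4, and the whole set stands together: the limit of > 10000 nM in this assay, at which 4 of the 4 values shown sit. The compounds shown leave open how phenyl and 4-chlorobenzyl on the aromatic nitrogen compare, and whether any compound on the shared core reaches a readable value.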